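Lengthening the Chain of Compound 2

A few compounds are considered here, and "the series" means these few. Any claim that something is new, unique, unknown or untested is made for them only; others in the source may bear on it.

Values so far in a functional assay, read by spectrophotometry; on this read-out lower numbers stand for an effect already at smaller amounts and higher numbers for an effect only at larger amounts of compound

Compound 1 `COc1cc(-c2cc(=O)c3ccc(O)cc3o2)cc(OC)c1OC` gives 26.4 nM
Compound 2 `COc1ccc(-c2cc(=O)c3ccc(OCCCN4CCC(C)CC4)cc3o2)cc1` gives 26.6 nM
Compound 3 `COc1ccc(-c2cc(=O)c3ccc(OCCCN4CCC(CCO)CC4)cc3o2)cc1` gives 22.8 nM

Compound 2 at 26.6 nM lies within the scatter of both compound 1 and compound 3, so it holds no separate place among the three. The next compound to be measured is compound 4 `COc1ccc(-c2cc(=O)c3ccc(OCCCCCN4CCC(C)CC4)cc3o2)cc1` and the change that leads to it reads 2-(4-methylpiperidin-1-yl)ethyl in place of 4-methylpiperidin-1-yl on a saturated chain carbon, three bonds along the chain from an oxygen on an aromatic ring on a saturated chain carbon, three bonds along the chain from an oxygen on an aromatic ring. Cut one bond further out, the same difference reads (4-methylpiperidin-1-yl)methyl to 3-(4-methylpiperidin-1-yl)propyl.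

Within the data shown here, only one measured step starts from compound 2, namely a 1.2-fold lower number from compound 2 to compound 3 (0.07 log units; within the scatter) and it stays within the scatter. That step is a different change, however, and leaves the chain from the oxygen untouched. Among the measured compounds shown here, no measured pair varies the chain length, so the evidence here is thin and the direction stays open. In this assay no step beyond the scatter is therefore expected, although the range has to stay wide. The estimated step is a 1.1-fold lower number from compound 2 to compound 4 (0.03 log units; within the scatter) and nothing larger is expected from these data. For compound 4 the estimate is 25 nM with an expected range from 8 nM to 80 nM in repeated measurements.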

Compound 4, half-maximal effective concentration: 31.7 nM
Beside the measured number, compound 4's estimate is 1.3-fold (0.10 log units) below it, within the range that was stated.
By their numbers in this assay, from the lowest: compounds 3, 1, 2 and 4 (each within the scatter of the next).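

In this assay, among these compounds, the chain from the oxygen is varied for the first time, and 2-(4-methylpiperidin-1-yl)ethyl in place of 4-methylpiperidin-1-yl on a saturated chain carbon, three bonds along the chain from an oxygen on an aromatic ring, gives a 1.2-fold higher number from compound 2 to compound 4 (0.08 log units; within the scatter). The earlier compounds shown here left this position untested, and this pair shows that, with the 4-methylpiperidin-1-yl ring kept, the added ethyl piece does not move the number in this assay past the usual scatter, while the comparison with the 4-(2-hydroxyethyl)piperidin-1-yl compound gives a 1.4-fold higher number from compound 3 to compound 4 (0.14 log units; within the scatter), so that step stays inside the scatter as well. Nothing measured here bears on why the number holds at this chain length.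

The compounds shown leave open whether a still longer chain, or a chain carrying an ether oxygen, would take the number in this assay beyond the scatter in either direction. They also leave open whether a morpholine or a piperazine at the end of the lengthened chain would behave as the 4-methylpiperidin-1-yl ring does.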